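This account rests on a few compounds, and the source may have more. Where it says the series, first, only, none or still open, it means among the compounds named here.

Measured compounds:
- compound 1 `Nc1ncnc2c1nc(Cl)n2Cc1ccccc1`: > 10 uM
- compound 2 `Nc1nc(N)c2nc(O)n(Cc3ccccc3)c2n1`: 10 uM

In a functional assay (spleen, spleen) for activation, with Mus musculus as the target (on this read-out higher numbers stand for an effect only at larger amounts of compound and lower numbers for an effect already at smaller amounts), compound 1 reaches only a limit of the assay, > 10 uM, and not a number. Compound 2 gives a measured value of 10 uM in this assay. For the measured compounds named here, the two measured compounds differ in more than one place, so no single step between them can be stated; the limit of > 10 uM in this assay, at which 1 of the 2 values shown sits, is the only evidence on where compound 1 stands, and it places compound 1 at the limit rather than at a fixed point.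

Compound 3 `Cc1nc2c(N)ncnc2n1Cc1ccccc1` is the compound not yet measured. It differs from compound 1 as follows: methyl in place of chloro on an aromatic carbon. For this change the expected step that the limit leaves unreadable from compound 1 to compound 3 is none beyond the scatter in this assay, since compound 1 is itself known only as a limit. For compound 3 the estimate in this assay is 20 uM, with a range from 7 uM to 60 uM, and a limit rather than a number is the more likely outcome.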

Compound 3, minimum effective concentration: > 10 uM
Compound 3: a limit, no number; the forecaster's own chance of this, stated with the estimate: 70%; the middle value is on the limit's open side.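

No step can be read for methyl in place of chloro, since compound 1 and compound 3 both stand only as limits in this assay, not as numbers: the limit of > 10 uM in this assay, at which 2 of the 3 values shown sit.

The compounds shown leave open whether compound 1 and compound 3 differ at all in this assay.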